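This account rests on a few compounds, and the source may have more. Where it says the series, first, only, none or still open, it means among the compounds named here.

Compound 1 `COc1cc2cc(Oc3ccc(NC(=O)Nc4cccc(C(F)(F)F)c4)cc3)c(C)nc2cc1OC` and compound 2 `COc1cc2cc(Oc3ccc(NC(=O)Nc4ccc(Cl)c(C(F)(F)F)c4)cc3)c(C)nc2cc1OC` share one core and differ only on the outer aryl ring. In a functional assay on NCI-H460 cells (Homo sapiens) for inhibition, read by sulforhodamine B assay, with a stated time of 48 h (a lower number here means that less compound is tolerated, a higher number that more compound is tolerated), compound 1 gives 34900 nM, and compound 2 gives 21100 nM; the step of a 1.7-fold lower number from compound 1 to compound 2 (0.22 log units; within the scatter) stays inside the scatter. On the numbers shown compound 2 sits beside compound 1, the two within the scatter of each other. Compound 3 `COc1cc2cc(Oc3ccc(NC(=O)Nc4ccc(Cl)c(Cl)c4)cc3)c(C)nc2cc1OC` is not yet measured; it differs from compound 2 by chloro in place of trifluoromethyl on an aromatic carbon. For the measured compounds named here, no measured step swaps these two groups, so the single step on record, a 1.7-fold lower number from compound 1 to compound 2 (0.22 log units; within the scatter), gives little guidance, and no change beyond the scatter in this assay is expected. For compound 3 the estimate is 25000 nM with a range of 10000 nM to 60000 nM, an expected step of a 1.2-fold higher number from compound 2 to compound 3 (0.07 log units; within the scatter).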

Compound 3, concentration lethal to 50% of the cells: 45800 nM
For compound 3 the middle estimate is 1.8-fold (0.26 log units) below the measured one; the range from low to high includes it.
By their numbers in this assay, from the lowest: compounds 2, 1 and 3 (each within the scatter of the next, the first and the last beyond it).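

Chloro in place of trifluoromethyl at this position, ortho to a chloro group, gives the first step in the series beyond the scatter in this assay: a 2.2-fold higher number from compound 2 to compound 3 (0.34 log units; beyond the scatter), and that step is modest. The wider change to 3,4-dichlorophenyl from 3-(trifluoromethyl)phenyl, a 1.3-fold higher number from compound 1 to compound 3 (0.12 log units; within the scatter), stays within the scatter. No evidence at hand accounts for either step. Still open, on these data alone, is whether an amine or a nitrile at this position would give a larger step, and whether the same swap gives a similar step without the chloro group.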